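This account rests on a few compounds, and the source may have more. Where it says the series, first, only, none or still open, it means among the compounds named here.

In a functional assay on SK-MEL cells (Homo sapiens) for cytotoxicity, read by MTT assay, with a stated time of 6 days (on this read-out lower numbers stand for an effect already at smaller amounts and higher numbers for an effect only at larger amounts of compound), compound 1 `COC(=O)c1c(-c2ccc([N+](=O)[O-])cc2)oc2cc(OC)ccc2c1=O` gives a true measured number of 2.84 ug/mL. Compound 2 `O=C(O)c1c(-c2ccc([N+](=O)[O-])cc2)oc2ccccc2c1=O` gives > 25 ug/mL, which is a limit of the assay and not a number. As far as these compounds go, this places compound 2 at the limit of > 25 ug/mL in this assay, at which 1 of the 2 values shown sits, so its exact position on the scale remains unknown.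

Compound 3 `COc1ccc2c(=O)c(C(=O)O)c(-c3ccc([N+](=O)[O-])cc3)oc2c1` differs from compound 2 in one place: methoxy in place of hydrogen on an aromatic carbon. In words, a methoxy group stands in place of hydrogen on an aromatic carbon. For the measured compounds named here, no measured pair of compounds isolates this single swap, so the data give no direct guide to its size or direction. Starting from compound 2 at > 25 ug/mL, the cautious expectation in this assay is no change beyond the usual scatter in either direction. Compound 3 may therefore also end up reported only as a limit. The expected outcome is a step that the limit leaves unreadable from compound 2 to compound 3. For compound 3 the estimated value is 30 ug/mL, with an expected range from 10 ug/mL to 80 ug/mL.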

Compound 3, concentration for half-maximal effect: > 25 ug/mL
Compound 3 gave a limit, no number; the forecaster's own chance of this, stated with the estimate: 65%; the middle value does not contradict the limit.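

Compound 3 joins compound 2 at the ceiling of this assay: the limit of > 25 ug/mL in this assay, at which 2 of the 3 values shown sit. With the methoxy group on the aromatic carbon, compound 3 still gives no measured number, and the step between compound 2 and compound 3 cannot be read. The new compound does supply the first readable comparison, since compound 1 and compound 3 both carry the methoxy group and differ only at the carbonyl side group: hydrogen in place of methyl on an oxygen next to a carbonyl group gives an at least 8.8-fold higher number from compound 1 to compound 3 (0.94 log units; beyond the scatter), and this lies beyond the scatter.

As far as these compounds go, how far past the limit compound 2 and compound 3 truly lie remains unknown, and any effect of the methoxy group on these two compounds could be hidden there. Also open, from the compounds shown here alone, is whether the measurable effect of compound 1 is tied to the methyl ester or would persist with another group in that place, such as an ethyl ester or an amide, and what the methoxy group contributes when that methyl ester is present.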